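Moving a trifluoromethyl group on a sulfonyl-linked ring

This account rests on a few compounds, and the source may have more. Where it says the series, first, only, none or still open, it means among the compounds named here.

This account follows three measured compounds and one unmeasured compound in a functional assay on LNCaP cells (Homo sapiens) for antiproliferative activity, read by propidium iodide staining, with a stated time of 96 h; a higher number here means a weaker inhibitor, a lower number a stronger inhibitor. Compound 1 `CC(O)(CSc1cccc(C(F)(F)F)c1)C(=O)Nc1ccc(S(F)(F)(F)(F)F)cc1` gives 18300 nM in this assay, and compound 2 `CC(O)(CSc1ccccc1C(F)(F)F)C(=O)Nc1ccc(S(F)(F)(F)(F)F)cc1` gives 12300 nM. Compound 2 differs from compound 1 by 2-(trifluoromethyl)phenyl in place of 3-(trifluoromethyl)phenyl on a sulfur, and the outcome is a 1.5-fold lower number from compound 1 to compound 2 (0.17 log units; within the scatter).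

Compound 3 `CC(O)(CS(=O)(=O)c1cccc(C(F)(F)F)c1)C(=O)Nc1cccc(S(F)(F)(F)(F)F)c1` gives 21800 nM in this assay. Compound 3 and compound 1 differ in more than one place, so the difference between these two cores is not broken down here. The values of compound 3 and compound 1 lie within the scatter of each other, as do those of compound 3 and compound 2.

Compound 4 `CC(O)(CS(=O)(=O)c1ccccc1C(F)(F)F)C(=O)Nc1cccc(S(F)(F)(F)(F)F)c1` is not yet measured. It differs from compound 3 by 2-(trifluoromethyl)phenyl in place of 3-(trifluoromethyl)phenyl on a sulfonyl sulfur. This is the same kind of change as that from compound 1 to compound 2, but not the same change: in the earlier pair the group sits on a sulfur whose other neighbours are a saturated chain carbon, whereas here it sits on a sulfonyl sulfur whose other neighbours are a saturated chain carbon. Because the earlier step was a 1.5-fold lower number from compound 1 to compound 2 (0.17 log units; within the scatter) and stayed within the scatter, compound 4 is expected to lie close to compound 3, with an estimated step of a 1.5-fold lower number from compound 3 to compound 4 (0.16 log units; within the scatter). The estimate for compound 4 in this assay is 15000 nM, with an expected range from 6000 nM to 40000 nM.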

Compound 4, half-maximal inhibitory concentration: 24900 nM
For compound 4 the middle estimate is 1.7-fold (0.22 log units) below the measured one; low and high end bracket the measured number.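

In this assay, moving the trifluoromethyl group on the sulfonyl-linked ring gives a 1.1-fold higher number from compound 3 to compound 4 (0.06 log units; within the scatter). Set beside the earlier step on the core of compound 1, this step shows that the same exchange leaves the number within the scatter on both cores, and that the two steps cannot be told apart: the same change on two cores in this assay, a 1.5-fold lower number (0.17 log units; within the scatter) from compound 1 to compound 2 and a 1.1-fold higher number (0.06 log units; within the scatter) from compound 3 to compound 4, 1.7-fold (0.23 log units) apart, within the scatter of two such steps. This does not show that the exchange has a real effect or a consistent direction on either core, and a single pair of steps does not establish that the result would carry over to any further core; the two cores also differ in more than one place, so the pairs cannot separate the contribution of each of those differences.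

The compounds shown leave open how the number would respond if the trifluoromethyl group were replaced by another group on the ring, such as a chlorine, a nitrile or a methoxy group, or removed to leave a plain phenyl. They also leave open how a sulfur and a sulfonyl sulfur would compare on an otherwise unchanged core, and where a sulfinyl link would stand.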